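Swapping methoxy for chloro in an antiproliferative compound

The source may hold more compounds than are shown below. What is called first, only, known or untested is meant among the compounds shown, and "the series" means these compounds.

In a functional assay on A549 cells (Homo sapiens) for antiproliferative activity, read by MTT assay, with a stated time of 72 h (on this read-out lower numbers stand for stronger inhibition and higher numbers for weaker inhibition), compound 1 `COc1ccc(N2C(=O)COc3ccc(-c4cnc(Cl)c(NS(=O)(=O)c5ccc(F)cc5)c4)cc32)cc1` gives 30400 nM while compound 2 `COc1ncc(-c2ccc3c(c2)N(c2ccc(F)cc2)C(=O)CO3)cc1NS(=O)(=O)c1ccc(F)cc1` gives 6500 nM and so holds the lower, stronger number of the two, by a gap beyond the usual scatter. Compound 3 `O=C1COc2ccc(-c3cnc(Cl)c(NS(=O)(=O)c4ccc(F)cc4)c3)cc2N1c1ccc(F)cc1` has not been measured yet. It has chloro in place of methoxy on an aromatic carbon of compound 2 chloro in place of methoxy on an aromatic carbon and this carbon lies next to the ring nitrogen. Among the measured compounds shown here, no measured step shows this swap alone. Compound 1 also carries the chloro group and gives 30400 nM as the weaker number, though it differs from compound 3 elsewhere too. The expected change is a 2.3-fold higher number from compound 2 to compound 3 (0.36 log units; beyond the scatter) in this assay toward a higher number, a modest loss only a little beyond the scatter. For compound 3 the estimated value is 15000 nM (expected range 5000 nM to 40000 nM).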

Compound 3, half-maximal inhibitory concentration: 22300 nM
For compound 3 the middle estimate is 1.5-fold (0.17 log units) below the measured one; the range from low to high includes it.
By their numbers in this assay, from the lowest: compound 2; then compounds 3 and 1 (each within the scatter of the next).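

In this assay, the swap on the aromatic carbon next to the ring nitrogen now has a size of its own: the change is a 3.4-fold higher number from compound 2 to compound 3 (0.54 log units; beyond the scatter) and shows that, of these two groups, methoxy goes with the stronger number at this place. The other single change gives a 1.4-fold lower number from compound 1 to compound 3 (0.13 log units; within the scatter) and so does not separate these two compounds while chloro is present. Nothing measured here accounts for the step from methoxy to chloro. On these data alone, whether an amine, a hydroxyl or an ethoxy group on this same carbon would match or improve on methoxy remains open. Also open, as far as these compounds go, is whether methoxy keeps its edge over chloro when the other methoxy group of compound 1 is present.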